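This account rests on a few compounds, and the source may have more. Where it says the series, first, only, none or still open, it means among the compounds named here.

Compound 2 `CN(C)c1ccc(C2CC(c3ccc(-n4ccnc4)cc3)=NN2S(C)(=O)=O)cc1` gives 11.3% in a functional assay on HCC1806 cells (Homo sapiens) for inhibition, read by sulforhodamine B assay, tested at 10 uM (on this read-out lower numbers stand for less inhibition and higher numbers for more inhibition at the one concentration tested (going by the name of the read-out)), the higher of the two numbers measured here, while compound 1 `CN(C)c1ccc(C2CC(c3ccc(-n4ccnc4)cc3)=NN2C(=O)CCCl)cc1` gives -5.2%. Going by the values given here, the only measured step, a number 16.5 percentage points higher from compound 1 to compound 2 (beyond the scatter), exchanges the entire group on the ring nitrogen rather than a part of it. Compound 3 `CN(C)c1ccc(C2CC(c3ccc(-n4ccnc4)cc3)=NN2S(=O)(=O)c2ccc([N+](=O)[O-])cc2)cc1` keeps the sulfonyl of compound 2 and differs by 4-nitrophenyl in place of methyl on a sulfonyl sulfur. Among the compounds with values here, since no measured step mirrors this change, the expectation rests on compound 2 alone, and the step expected is a number 3.7 percentage points higher from compound 2 to compound 3 (within the scatter). Compound 3 is thus expected to give 15%, most likely between -5% and 35%.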

Compound 3, a percentage reported as inhibition, at one concentration (the size of the read-out at that concentration, not a potency): 46.6%
Estimate against measurement, compound 3: 31.6 percentage points below; measured number above the stated range.
By their numbers in this assay, from the lowest: compound 1; then compound 2; then compound 3.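

With the sulfonyl kept, the group on the sulfonyl sulfur turns out to matter in this assay: 4-nitrophenyl in place of methyl gives a number 35.3 percentage points higher from compound 2 to compound 3 (beyond the scatter). Exchanging the whole group on the ring nitrogen, (4-nitrophenyl)sulfonyl in place of (2-chloroethyl)carbonyl, gives a number 51.8 percentage points higher from compound 1 to compound 3 (beyond the scatter). No measurement here explains the rise. The compounds shown leave open whether a plain phenyl on the sulfonyl sulfur would give a similar number, and so whether the rise goes with the aromatic ring or with its nitro group.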